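The source may report more compounds than this note shows. Statements on the series, on what has been measured and on what is new or still open speak of the compounds shown alone.

Three compounds on the shared core have numbers in a functional assay on A549 cells (Homo sapiens) for cytotoxicity, read by MTT assay, with a stated time of 48 h (a higher number here means a weaker inhibitor, a lower number a stronger inhibitor), so far. Compound 1 `COc1ccc(N/C(CCNC2=CC(=O)c3ccccc3C2=O)=N\S(=O)(=O)c2ccc(C)cc2)cc1` gives 25500 nM. Compound 2 `Cc1ccc(S(=O)(=O)/N=C(/CCNC2=CC(=O)c3ccccc3C2=O)Nc2cccc(C)c2)cc1` gives 18700 nM. Compound 3 `COc1ccc(N/C(CCNC2=CC(=O)c3ccccc3C2=O)=N\S(=O)(=O)c2ccc(C)cc2)cc1OC` gives 20500 nM. Compound 3 stands second highest of the three, but the step of a 1.2-fold lower number from compound 1 to compound 3 (0.09 log units; within the scatter) and the step of a 1.1-fold higher number from compound 2 to compound 3 (0.04 log units; within the scatter) are both within the scatter, so no order among the three is claimed.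

Compound 4 `COc1ccc(N/C(CCNC2=CC(=O)C(C)=C(C)C2=O)=N\S(=O)(=O)c2ccc(C)cc2)cc1OC` differs from compound 3 in one place: a group of 10 heavy atoms (8 carbon, 2 oxygen; one six-membered non-aromatic ring of carbon only) in place of a group of 12 heavy atoms (10 carbon, 2 oxygen; one six-membered non-aromatic ring of carbon only, one six-membered aromatic ring of carbon only), on an amine nitrogen. Going by the values given here, none of the measured steps touches that part of the molecule. The steps of a 1.4-fold lower number from compound 1 to compound 2 (0.13 log units; within the scatter) and a 1.1-fold higher number from compound 2 to compound 3 (0.04 log units; within the scatter) exchange the aryl group on the other amine nitrogen, and the step of a 1.2-fold lower number from compound 1 to compound 3 (0.09 log units; within the scatter) adds a methoxy on an aromatic carbon; all three stayed within the scatter, which says only that variation elsewhere in the series has been flat. Among the compounds with values here, the group that leaves carries a six-membered aromatic ring of carbon only, the group that enters carries none, and no measured pair speaks to that. The expected step of a 1.0-fold lower number from compound 3 to compound 4 (0.01 log units; within the scatter) is therefore set to none beyond the scatter, with a wide range to cover the lack of precedent. Compound 4 is estimated at 20000 nM, between 6000 nM and 70000 nM.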

Compound 4, half-maximal inhibitory concentration: 15500 nM
Beside the measured number, compound 4's estimate is 1.3-fold (0.11 log units) above it; the measured number falls inside the stated range.
By their numbers in this assay, from the lowest: compounds 4, 2, 3 and 1 (each within the scatter of the next).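

Exchanging the group of 12 heavy atoms for the group of 10 heavy atoms, on an amine nitrogen whose other neighbours are saturated chain carbon, gives a 1.3-fold lower number from compound 3 to compound 4 (0.12 log units; within the scatter) in this assay. Going by these compounds alone, the earlier steps all lay on the other amine nitrogen or its aryl group, so this is the first reading at this position: the six-membered aromatic ring of carbon only can leave, and the count of double bonds outside aromatic rings can go from 3 to 4, with no step beyond the scatter in this pair. No measurement shown here accounts for this flat result, so it stands as an observation without an explanation.

From the compounds shown here alone, this exchange has been read at this position only with the 3,4-dimethoxyphenyl group on the other amine nitrogen, so whether it stays as flat with 3-methylphenyl or 4-methoxyphenyl there remains open. Also open, going by these compounds, is whether chlorine or an amine on the non-aromatic ring of the entering group, or a longer chain in place of the saturated chain, would move the number beyond the scatter.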